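Heteroaryl amide change from compound 3 to compound 4

A few compounds are considered here, and "the series" means these few. Any claim that something is new, unique, unknown or untested is made for them only; others in the source may bear on it.

Compound 3 `COc1cc(N(C)C)c(NC(=O)c2ccnc(Cl)n2)cc1Nc1nccc(-c2cn(C)c3ccccc23)n1` gives the lowest number of the three measured in a functional assay on NCI-H1975 cells (Homo sapiens) for antiproliferative activity, read by MTT assay, with a stated time of 72 h (a lower number here means a stronger inhibitor, a higher number a weaker inhibitor), at 3660 nM. Compound 1 `COc1cc(N(C)C)c(NC(=O)c2ccncc2OC)cc1Nc1nccc(-c2cn(C)c3ccccc23)n1` gives 12100 nM and compound 2 `COc1cc(N(C)C)c(NC(=O)c2ccccn2)cc1Nc1nccc(-c2cn(C)c3ccccc23)n1` gives 10400 nM; these two lie within the scatter of each other, as a 1.2-fold lower number from compound 1 to compound 2 (0.07 log units; within the scatter). The other two steps are modest: a 3.3-fold lower number from compound 1 to compound 3 (0.52 log units; beyond the scatter) and a 2.8-fold lower number from compound 2 to compound 3 (0.45 log units; beyond the scatter). Compound 4 `COc1cc(N(C)C)c(NC(=O)c2c[nH]cn2)cc1Nc1nccc(-c2cn(C)c3ccccc23)n1` carries 1H-imidazol-4-yl in place of 2-chloropyrimidin-4-yl on a carbonyl carbon. All measured steps touch the same carbonyl carbon, but none brings in a five-membered ring or a hydrogen-bond donor, so they guide only loosely; the two heteroaryls without chlorine, in compound 1 and compound 2, both gave higher numbers than compound 3. The expected step is a 2.0-fold higher number from compound 3 to compound 4 (0.31 log units; beyond the scatter), a modest rise in this assay. Compound 4 is estimated at 7500 nM, with a range of 2500 nM to 22000 nM.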

Compound 4, half-maximal inhibitory concentration: 3120 nM
Beside the measured number, compound 4's estimate is 2.4-fold (0.38 log units) above it, and the stated range covers the measured number.
By their numbers in this assay, from the lowest: compounds 4 and 3 (each within the scatter of the next); then compounds 2 and 1 (each within the scatter of the next).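

In this assay, the five-membered 1H-imidazol-4-yl, which brings a hydrogen-bond donor, reads level with 2-chloropyrimidin-4-yl on this carbonyl carbon: a 1.2-fold lower number from compound 3 to compound 4 (0.07 log units; within the scatter). Neither chlorine nor a six-membered ring is therefore needed here for a number in this range, and the same change separates 1H-imidazol-4-yl from the other two heteroaryls, with a 3.3-fold lower number from compound 2 to compound 4 (0.52 log units; beyond the scatter) and a 3.9-fold lower number from compound 1 to compound 4 (0.59 log units; beyond the scatter). No supporting measurement bears on why these steps occur.

Open, going by these compounds, is how 1-methylimidazol-4-yl, pyrrol-2-yl or plain phenyl on the same carbonyl carbon would read.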